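Swapping a Chlorophenyl for a Thiophene on the Core

The source may hold more compounds than are shown below. What is called first, only, known or untested is meant among the compounds shown, and "the series" means these compounds.

Compound 3 `Nc1cccc(-c2cn3nc(-c4ccc(Cl)cc4)sc3n2)c1` gives 160000 nM in a functional assay on HeLa cells (Homo sapiens) for inhibition, read by cell counting, with a stated time of 4 days (on this read-out lower numbers stand for stronger inhibition and higher numbers for weaker inhibition), the highest of the three numbers here and so the weakest inhibition of the group. Compound 1 `Nc1cccc(-c2cn3nc(Cc4ccccc4)sc3n2)c1` gives 24000 nM and compound 2 `C=C(Br)C(=O)Nc1cccc(-c2cn3nc(-c4cccs4)sc3n2)c1` gives 670 nM. Compound 4 `Nc1cccc(-c2cn3nc(-c4cccs4)sc3n2)c1` differs from compound 3 by thiophen-2-yl in place of 4-chlorophenyl on an aromatic carbon. For the measured compounds named here, the only measured step at this place, a 6.7-fold higher number from compound 1 to compound 3 (0.82 log units; beyond the scatter), shows that the group there shifts the number beyond the scatter. Compound 2 carries the same thiophen-2-yl but also a different group on its other ring, so its value cannot be split into parts. Compound 4 is therefore expected to move back toward compound 1, by a 4.0-fold lower number from compound 3 to compound 4 (0.60 log units; beyond the scatter). Compound 4 is estimated at 40000 nM, within a range of 10000 nM to 160000 nM.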

Compound 4, half-maximal inhibitory concentration: > 250000 nM
Compound 4: no number, only a limit; the forecaster's own chance of this, stated with the estimate: 10%; middle value at least 6.2-fold (0.79 log units) away from the limit.
By their numbers in this assay, from the lowest: compound 2; then compound 1; then compound 3. At a limit, above all of these: compound 4.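

In this assay compound 4 gives > 250000 nM as a limit of the assay, not a number. With an at least 1.5-fold higher number from compound 3 to compound 4 (0.19 log units; that floor lies within the scatter) thiophen-2-yl and 4-chlorophenyl cannot be put in order at this position, while an at least 10-fold higher number from compound 1 to compound 4 (1.01 log units; beyond the scatter) leaves benzyl with the lower number of the groups there. The change on the nitrogen counts for much more: an at least 370-fold higher number from compound 2 to compound 4 (2.57 log units; beyond the scatter) ties the low number of compound 2 to its (1-bromoethenyl)carbonyl group on the same thiophen-2-yl core. Open remains how a plain acetyl on that nitrogen would read, and whether a phenylethyl chain in place of benzyl would lower the number further.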